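Side-chain exchange from compound 2 to compound 3

The compounds below may be only part of what the source reports. "The series", "measured", "known", "first", "only" and "open" are said of these compounds alone.

Going by the values given here, in an ADME assay on microsomes from liver (Homo sapiens) for metabolic stability (a lower number here means slower removal, a higher number faster removal of the compound), compound 2 (`O=C(N[C@H]1CN(S(=O)(=O)c2ccccc2)C[C@@H]1C(=O)NC[C@@H]1CCCN1)c1cc(-c2ccccc2Cl)on1`) gives 9.7 mL.min-1.g-1, the only true number in this pair. Compound 1 (`O=C(N[C@H]1CN(S(=O)(=O)c2ccccc2)C[C@@H]1C(=O)N[C@H]1CCCNC1)c1cc(-c2ccccc2)on1`) gives < 3 mL.min-1.g-1, which is a limit of the assay and not a number. Among the compounds with values here, the two compounds differ in more than one place, so they provide no measured step.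

Compound 3 (`CC(=O)N1CCC[C@H](NC(=O)[C@H]2CN(S(=O)(=O)c3ccccc3)C[C@@H]2NC(=O)c2cc(-c3ccccc3Cl)on2)C1`) keeps the rest of compound 2 and changes one substituent: 1-acetylpiperidin-3-yl in place of (pyrrolidin-2-yl)methyl on an amide-type nitrogen. In words, 1-acetylpiperidin-3-yl stands in place of (pyrrolidin-2-yl)methyl on an amide-type nitrogen. Within the data shown here, no measured step covers this change, so the expectation is anchored on compound 2 at 9.7 mL.min-1.g-1 alone, and the range is kept wide.

An upward move in this assay is expected, estimated as a 2.3-fold higher number from compound 2 to compound 3 (0.36 log units; beyond the scatter). For compound 3 the estimated value is 22 mL.min-1.g-1, with an expected range from 8 mL.min-1.g-1 to 60 mL.min-1.g-1.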

Compound 3, intrinsic clearance in microsomes in the Homo sapiens assay: > 300 mL.min-1.g-1
Compound 3 ended at the assay's limit; the forecaster's own chance of this, stated with the estimate: 5%; at least 13-fold (1.13 log units) between middle value and limit.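

Going by these compounds alone, at this amide-type nitrogen, 1-acetylpiperidin-3-yl in place of (pyrrolidin-2-yl)methyl gives in the Homo sapiens assay an at least 30-fold higher number from compound 2 to compound 3 (1.49 log units; beyond the scatter), the only measured step, which shows that this position bears strongly on the read-out. In the Homo sapiens assay compound 3 gives > 300 mL.min-1.g-1, a limit of the assay and not a number. The same change also comes with a rise in a physicochemical assay for lipophilicity, measured as octanol-water partition, at pH 7.4; on this read-out higher numbers stand for higher lipophilicity and lower numbers for lower lipophilicity: the measured distribution coefficient of compound 2, 1.5, and of compound 3, 3.5, a number 2.00 log units higher (beyond the scatter). In the physicochemical assay compound 2 gives 1.5 and compound 3 gives 3.5.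

The acetyl group, the six-membered ring and the loss of the (pyrrolidin-2-yl)methyl group all change together in this one step, so the compounds shown do not tell which of them carries it. Also open, going by these compounds, is how 1-methanesulfonylpiperidin-3-yl, or a side chain ending in a carboxylic acid, would read at this position in either assay.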